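Compound 3 to compound 4: replacing the vinylsulfonyl group

The compounds below may be only part of what the source reports. "The series", "measured", "known", "first", "only" and "open" are said of these compounds alone.

- compound 1 `C=CS(=O)(=O)N1CCN(c2ncnc3sc(-c4ccccc4)cc23)CC1`: 21100 nM
- compound 2 `C=CS(=O)(=O)N1CCN(c2ncnc3sc(-c4ccc(C(F)(F)F)cc4)cc23)CC1`: 7080 nM
- compound 3 `C=CS(=O)(=O)N1CCN(c2ncnc3sc(-c4ccc(N5CCN(C)CC5)cc4)cc23)CC1`: 8760 nM

All values come from a functional assay on MDA-MB-436 cells (Homo sapiens) for antiproliferative activity, read by MTT assay, with a stated time of 48 h; on this read-out lower numbers stand for stronger inhibition and higher numbers for weaker inhibition. Compound 3 stands level with compound 2, given a 1.2-fold higher number from compound 2 to compound 3 (0.09 log units; within the scatter). Compound 1 has the highest number of the three, and the gap to the third compound is a 2.4-fold lower number from compound 1 to compound 3 (0.38 log units; beyond the scatter).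

Compound 4 `CCCNC(=O)N1CCN(c2ncnc3sc(-c4ccc(N5CCN(C)CC5)cc4)cc23)CC1` keeps the aromatic substituent of compound 3 and differs as follows: propylcarbamoyl in place of vinylsulfonyl on an amine nitrogen in a ring. In words, this is propylcarbamoyl in place of vinylsulfonyl on an amine nitrogen in a ring.

For the measured compounds named here, no measured step touches that nitrogen substituent. All three steps change the aromatic carbon instead, and the largest, a 3.0-fold lower number from compound 1 to compound 2 (0.47 log units; beyond the scatter), is only modest. They give no direction for this change, so no step beyond the scatter is expected in this assay, though with low confidence.

The estimated step is a 1.1-fold lower number from compound 3 to compound 4 (0.04 log units; within the scatter). For compound 4 the expected value is 8000 nM. The estimated range for compound 4 runs from 2500 nM to 25000 nM.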

Compound 4, half-maximal inhibitory concentration: 12400 nM
For compound 4 the middle estimate is 1.6-fold (0.19 log units) below the measured one; the measured number falls inside the stated range.
By their numbers in this assay, from the lowest: compounds 2, 3, 4 and 1 (each within the scatter of the next, the first and the last beyond it).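

For the compounds shown here, this is the first reading at the amine nitrogen in the ring, where all earlier steps changed only the aromatic carbon. In this assay, exchanging vinylsulfonyl for propylcarbamoyl gives a 1.4-fold higher number from compound 3 to compound 4 (0.15 log units; within the scatter), so with 4-methylpiperazin-1-yl held on the aromatic ring, this pair shows no change beyond the scatter, even though the entering group has a hydrogen-bond donor and the leaving group has none. No available evidence bears on this result, so the comparison describes the outcome without explaining it.

A single pair leaves open whether the same exchange would behave alike with trifluoromethyl or hydrogen on the aromatic carbon. Also open, from the compounds shown here alone, is how a longer chain on the carbamoyl nitrogen, a phenylcarbamoyl group or an acryloyl group would read at this nitrogen.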